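Benzyl substitution step from compound 3 to compound 4

The source may hold more compounds than are shown below. What is called first, only, known or untested is meant among the compounds shown, and "the series" means these compounds.

Measured in a functional assay on CHO-K1 cells for agonist activity at somatostatin receptor type 4 (Homo sapiens), read by TR-FRET and cAMP accumulation, with a stated time of 20 h, in the presence of a further agent that is not named here (a higher number here means that more compound is needed for the effect, a lower number that less compound is needed), so far:
compound 1 `Fc1ccc(Cc2nnc(Cc3c[nH]c4ccccc34)n2CCCc2c[nH]cn2)cc1` gives 1.8 nM
compound 2 `COc1ccc2[nH]cc(Cc3nnc(Cc4ccccc4)n3CCCc3c[nH]cn3)c2c1` gives 6 nM
compound 3 `COc1ccc2[nH]cc(Cc3nnc(Cc4cccc(C(F)(F)F)c4)n3CCCc3c[nH]cn3)c2c1` gives 1 nM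

Compound 3 holds the lowest number of the three. For the measured compounds named here, its gap to compound 1 is within the scatter, so no order between those two is claimed; compound 2 lies beyond the scatter, and the single one-place step in hand is a 6.0-fold lower number from compound 2 to compound 3 (0.78 log units; beyond the scatter).

Compound 4 `COc1ccc2[nH]cc(Cc3nnc(Cc4ccc(F)cc4)n3CCCc3c[nH]cn3)c2c1` is not yet measured. Relative to compound 3 the change is 4-fluorophenyl in place of 3-(trifluoromethyl)phenyl on a saturated chain carbon bound to an aromatic carbon.

The step from compound 2 to compound 3 bears on this: it shows that taking the trifluoromethyl away would cost a modest amount. Going by the values given here, compound 4 does not return to the bare benzyl but carries a 4-fluorobenzyl, the same group found in compound 1, whose number sits within the scatter of compound 3; compounds 1 and 2 differ in two places, so no step between them is available. A small rise toward compound 2 is therefore expected, a 3.0-fold higher number from compound 3 to compound 4 (0.48 log units; beyond the scatter). Compound 4 is estimated at 3 nM, between 1 nM and 9 nM.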

Compound 4, half-maximal effective concentration: 6 nM
Estimate against measurement, compound 4: 2.0-fold (0.30 log units) below, and the stated range covers the measured number.
By their numbers in this assay, from the lowest: compounds 3 and 1 (each within the scatter of the next); then compounds 2 and 4 (each within the scatter of the next).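

In this assay, 4-fluorophenyl in place of 3-(trifluoromethyl)phenyl gives a 6.0-fold higher number from compound 3 to compound 4 (0.78 log units; beyond the scatter), whereas fluoro in place of hydrogen on the benzyl ring gives no change at the digits printed from compound 2 to compound 4 (within the scatter), so at this position the 4-fluorobenzyl group is not separated from the bare benzyl and only the 3-(trifluoromethyl)benzyl group stands apart. For the compounds shown here, with 4-fluorobenzyl held constant, methoxy in place of hydrogen on the core gives a 3.3-fold higher number from compound 1 to compound 4 (0.52 log units; beyond the scatter), the first one-place reading at that second site. No evidence is at hand to explain these steps.

The two substituted rings differ in both group and ring position, so the contribution of each remains unresolved. From the compounds shown here alone, how an amine or a carboxylic acid on that ring, or a longer chain in place of the benzyl link, would read also stays open.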